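Aryl sulfonamide series: working notes toward compound 4

The compounds below may be only part of what the source reports. "The series", "measured", "known", "first", "only" and "open" are said of these compounds alone.

Measured so far:
compound 1 `CCc1ccccc1NS(=O)(=O)c1ccc(N2CCNC2=O)cc1` gives 180 nM in a functional assay on M21 cells (Homo sapiens) for antiproliferative activity, read by sulforhodamine B assay, with a stated time of 48 h; a higher number here means a weaker inhibitor, a lower number a stronger inhibitor
compound 2 `Cc1ccccc1NS(=O)(=O)c1ccc(N2CCNC2=O)cc1` gives 150 nM in this assay
compound 3 `O=C1NCCN1c1ccc(S(=O)(=O)Nc2ccc(Br)cc2)cc1` gives 130 nM in this assay

Compound 1 has the highest of the three numbers, but none of the gaps carries weight: to compound 2 the step is a 1.2-fold lower number from compound 1 to compound 2 (0.08 log units; within the scatter), to compound 3 it is a 1.4-fold lower number from compound 1 to compound 3 (0.14 log units; within the scatter), and between the other two it is a 1.2-fold lower number from compound 2 to compound 3 (0.06 log units; within the scatter). All three compounds therefore sit in one band, with no order among them.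

Compound 4 `O=C1NCCN1c1ccc(S(=O)(=O)Nc2cccc(Cl)c2)cc1` is the next member. Against compound 1 the change is 3-chlorophenyl in place of 2-ethylphenyl on a sulfonamide nitrogen. For the measured compounds named here, the steps that bear on this are the two earlier swaps of the aryl group on the sulfonamide nitrogen, from compound 1 to compound 3 and from compound 2 to compound 3, both within the scatter, and the removal of the methyl from compound 1 to compound 2, also within the scatter. Going by the values given here, nothing measured so far shows that the aryl group on the sulfonamide nitrogen moves the number.

Compound 4 is thus expected to stay in the same band, a step of a 1.2-fold lower number from compound 1 to compound 4 (0.08 log units; within the scatter) from compound 1. The estimate for compound 4 in this assay is 150 nM, with a range from 70 nM to 320 nM.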

Compound 4, half-maximal inhibitory concentration: 25 nM
The estimate for compound 4 lay 6.0-fold (0.78 log units) above the measured number; the whole stated range lies above it.
By their numbers in this assay, from the lowest: compound 4; then compounds 3, 2 and 1 (each within the scatter of the next).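

The aryl group on the sulfonamide nitrogen does move the number in this assay: 3-chlorophenyl gives a 7.2-fold lower number from compound 1 to compound 4 (0.86 log units; beyond the scatter) when it replaces 2-ethylphenyl, a 6.0-fold lower number from compound 2 to compound 4 (0.78 log units; beyond the scatter) when it replaces 2-methylphenyl and a 5.2-fold lower number from compound 3 to compound 4 (0.72 log units; beyond the scatter) when it replaces 4-bromophenyl. The earlier swaps at this position stayed within the scatter, so this position looked flat only across those three aryl groups; compound 4 is the strongest inhibitor of the four, and compounds 1, 2 and 3 remain one band. No measurement on hand says why 3-chlorophenyl stands apart from the other three aryl groups.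

Compound 3 and compound 4 differ in both the halogen and its place in the group name, so the compounds shown cannot tell whether the lower number follows the chlorine or its place on the phenyl ring, a question that 4-chlorophenyl and 3-bromophenyl would separate. Also open, from the compounds shown here alone, is whether a halogen is needed at all, which 3-methylphenyl or 3-aminophenyl on the same sulfonamide nitrogen would address.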